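This account rests on a few compounds, and the source may have more. Where it says the series, first, only, none or still open, it means among the compounds named here.

Measured so far in a functional assay on P388 cells (Mus musculus) for inhibition, read by MTT assay; a lower number here means a stronger inhibitor, a higher number a weaker inhibitor:

Compound 1, `CC(=O)OC1C#CCCCCC#C/C1=C\c1ccccc1`, gives 48000 nM.
Compound 2, `CC(=O)OC1C#CCCCCC#C/C1=C\c1ccc2ccccc2c1`, gives 2800 nM.
Compound 3, `COCC(=O)OC1C#CCCCCC#C/C1=C\c1ccccc1`, gives 23000 nM.

Compound 1 and compound 2 carry different cores, and the difference between the two cores is not broken down here. Of the three numbers, compound 2 shows the lowest, and its gap to each of the other two lies beyond the usual scatter. Within the core of compound 1, one change has been measured: methoxy in place of hydrogen on a saturated chain carbon bound to a carbonyl carbon. It produced a 2.1-fold lower number from compound 1 to compound 3 (0.32 log units; beyond the scatter).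

Compound 4, `COCC(=O)OC1C#CCCCCC#C/C1=C\c1ccc2ccccc2c1`, has not yet been measured in this assay. It arises from compound 2 by methoxy in place of hydrogen on a saturated chain carbon bound to a carbonyl carbon. This is the same change, made at the same kind of place, that turned compound 1 into compound 3. The expectation for compound 4 therefore rests on that single earlier step; from compound 2 the estimated step is a 2.2-fold lower number from compound 2 to compound 4 (0.33 log units; beyond the scatter), because the matching step a 2.1-fold lower number from compound 1 to compound 3 (0.32 log units; beyond the scatter) was modest. Compound 4 is thus expected to give about 1300 nM, most likely between 500 nM and 3500 nM.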

Compound 4, half-maximal inhibitory concentration: 28000 nM
Beside the measured number, compound 4's estimate is 22-fold (1.33 log units) below it, and the stated range ends below it.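

In this assay, methoxy in place of hydrogen on a saturated chain carbon bound to a carbonyl carbon gave a 10-fold higher number from compound 2 to compound 4 (1.00 log units; beyond the scatter), the opposite direction to the earlier step on the other core. The change therefore does not carry over between these two cores, and its effect on one core gave no reliable guide to its effect on the other: the same change on two cores in this assay, a 2.1-fold lower number (0.32 log units; beyond the scatter) from compound 1 to compound 3 and a 10-fold higher number (1.00 log units; beyond the scatter) from compound 2 to compound 4, 21-fold (1.32 log units) apart, beyond the scatter of two such steps

For the compounds shown here, this shows that the result of the change depends on the core that carries it, but with only two pairs it does not show what in the cores is responsible, or how the change would behave on a third core.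

The compounds shown hold only hydrogen or methoxy at this place, so it remains open how a longer chain such as ethoxy, an amine or a carboxylic acid would behave there on each core. Going by these compounds, it also remains open whether either of the two opposite steps is the more typical one for this series.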